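Branching the diol chain of compound 2

The compounds below may be only part of what the source reports. "The series", "measured", "known", "first", "only" and "open" are said of these compounds alone.

Within the data shown here, in an ADME assay on S9 fraction from liver (Rattus norvegicus, strain Sprague-Dawley) for metabolic stability, read by LC-MS, using NADPH, with stated times of 5 min and 60 min, tested at 5 uM (on this read-out higher numbers stand for a more stable compound and lower numbers for a less stable compound), compound 1 (`COc1cc(C2CN(C(=O)c3cc(OC[C@H](O)CO)ccn3)C2)ccc1OCc1ccc(C2CC2)cc1`) gives 67% and compound 2 (`COc1cc(C2CN(C(=O)c3cc(COC[C@H](O)CO)ccn3)C2)ccc1OCc1ccc(C2CC2)cc1`) gives 52%, the lowest of the two numbers so far. Compound 3 (`COc1cc(C2CN(C(=O)c3cc(COCC(CO)CO)ccn3)C2)ccc1OCc1ccc(C2CC2)cc1`) differs from compound 2 as follows: 2-hydroxy-1-(hydroxymethyl)ethyl in place of 1,2-dihydroxyethyl on a saturated chain carbon bound to an oxygen on a saturated carbon. Its chain therefore ends in 3-hydroxy-2-(hydroxymethyl)propoxy rather than 2,3-dihydroxypropoxy.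

Among the measured compounds shown here, only one measured step exists: a number 15 percentage points lower from compound 1 to compound 2 (beyond the scatter). That modest step is a change on an aromatic carbon, whereas the new change sits on a saturated chain carbon bound to an oxygen on a saturated carbon. For the measured compounds named here, it gives no direct guide, and no measured step covers this exchange. No step beyond the scatter is expected in this assay, in either direction, so the estimate stays close to compound 2 at 52%. The step expected is a number 2 percentage points lower from compound 2 to compound 3 (within the scatter). The estimated value for compound 3 is 50%, with an expected range of 36% to 64%.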

Compound 3, percent of the compound remaining: 29%
Estimate against measurement, compound 3: 21 percentage points above, outside the stated range (below it).
By their numbers in this assay, from the lowest: compound 3; then compound 2; then compound 1.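

In this assay, the saturated chain carbon bound to an oxygen on a saturated carbon proves sensitive: 2-hydroxy-1-(hydroxymethyl)ethyl in place of 1,2-dihydroxyethyl gives a number 23 percentage points lower from compound 2 to compound 3 (beyond the scatter) even though the counts of hydrogen-bond donors and acceptors stay the same. Among these compounds, replacing 2,3-dihydroxypropoxy on the aromatic carbon with (3-hydroxy-2-(hydroxymethyl)propoxy)methyl gives a number 38 percentage points lower from compound 1 to compound 3 (beyond the scatter) and is the largest step so far. Nothing at hand accounts for either step.

Still open, from the compounds shown here alone, is whether 3-hydroxy-2-(hydroxymethyl)propoxy directly on the aromatic carbon would give a number closer to that of compound 1 or to that of compound 3. Also open, going by these compounds, is how an amine or a carboxylic acid at the end of the chain would compare with the diol of compound 2.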